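Replacing an Aromatic Ring with Cycloheptyl on the Ring Amine

This account rests on a few compounds, and the source may have more. Where it says the series, first, only, none or still open, it means among the compounds named here.

Compound 1, `COc1ccc(N2CCN(Cc3csc(N)c3C(=O)c3ccc(Cl)cc3)CC2)cc1`: 0%
Compound 2, `Nc1scc(CN2CCN(c3ccc(OC(F)(F)F)cc3)CC2)c1C(=O)c1ccc(Cl)cc1`: 0%

In an assay on CHO cells for displacement of a labelled ligand from adenosine receptor A1 (Homo sapiens), read by scintillation counting, with a stated time of 120 min, tested at 10 uM (on this read-out lower numbers stand for less inhibition and higher numbers for more inhibition at the one concentration tested (going by the name of the read-out)), compound 1 gives 0% and compound 2 gives 0%. Among the measured compounds shown here, the one measured step, no change at the digits printed from compound 1 to compound 2 (within the scatter), leaves compound 2 level with compound 1 in this assay. Compound 3, `Nc1scc(CN2CCN(C3CCCCCC3)CC2)c1C(=O)c1ccc(Cl)cc1`, differs from compound 2 by cycloheptyl in place of 4-(trifluoromethoxy)phenyl on an amine nitrogen in a ring. For the measured compounds named here, no measured step bears directly on this change, so the two flat values are the only guide. Compound 3 is therefore expected to show no inhibition beyond the scatter, a step of a number 5 percentage points higher from compound 2 to compound 3 (within the scatter), with an estimated 5% ranging from -5% to 25%.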

Compound 3, a percentage reported as inhibition, at one concentration (the size of the read-out at that concentration, not a potency): 0%
The estimate for compound 3 lay 5 percentage points above the measured number; the range from low to high includes it.
By their numbers in this assay, from the lowest: compounds 1, 2 and 3 (each within the scatter of the next).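

In this assay, cycloheptyl in place of 4-(trifluoromethoxy)phenyl gives no change at the digits printed from compound 2 to compound 3 (within the scatter), and cycloheptyl in place of 4-methoxyphenyl gives no change at the digits printed from compound 1 to compound 3 (within the scatter). The earlier step only altered a group on the aromatic ring, whereas here the whole aromatic ring gives way to a non-aromatic one, and the reading stays flat. No supporting measurement accounts for this flat result.

With all three compounds showing no inhibition, the effect of this position on binding cannot yet be judged. From the compounds shown here alone, whether a benzyl group or a plain methyl on this nitrogen would produce any inhibition remains open.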